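The source may hold more compounds than are shown below. What is called first, only, known or untested is meant among the compounds shown, and "the series" means these compounds.

Measured compounds:
compound 1, `CN(Cc1ccccc1)CC1CCN(CCCc2c[nH]c3ccc(-n4cnnc4)cc23)CC1`, 0.95 nM
compound 2, `CN(Cc1ccccc1)C1CCN(CCCc2c[nH]c3ccc(-n4cnnc4)cc23)CC1`, 2.2 nM
compound 3, `c1ccc(CNC2CCN(CCCc3c[nH]c4ccc(-n5cnnc5)cc34)CC2)cc1`, 4.8 nM

All three numbers come from an assay on CHO cells for binding affinity to 5-hydroxytryptamine receptor 1D (Homo sapiens); a lower number here means a stronger inhibitor, a higher number a weaker inhibitor. Compound 3 stands at the highest number of the three: a 2.2-fold higher number from compound 2 to compound 3 (0.34 log units; beyond the scatter) and a 5.1-fold higher number from compound 1 to compound 3 (0.70 log units; beyond the scatter) both set it apart from the others beyond the scatter, with a 2.3-fold higher number from compound 1 to compound 2 (0.36 log units; beyond the scatter) the remaining step among the measured set.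

Compound 4, `C[C@@H](NC1CCN(CCCc2c[nH]c3ccc(-n4cnnc4)cc23)CC1)c1ccccc1`, is compound 3 with methyl in place of hydrogen on a saturated chain carbon bound to an amine nitrogen and an aromatic carbon; cut one bond further out, the change reads benzylamino to (1-phenylethyl)amino. For the measured compounds named here, none of the measured steps touches this carbon: the one step that adds or removes a methyl, from compound 2 to compound 3, sits on the amine nitrogen, not on the chain carbon, so it does not bear directly on the new change. With no step of this kind in the series, the default expectation in this assay is a change of no more than the scatter, in no settled direction.

Compound 4 is therefore expected at 4.5 nM, range 1.5 nM to 13 nM, which means an expected step of a 1.1-fold lower number from compound 3 to compound 4 (0.03 log units; within the scatter).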

Compound 4, half-maximal inhibitory concentration: 0.35 nM
The estimate for compound 4 lay 13-fold (1.11 log units) above the measured number; the measured number lies below the stated range.
By their numbers in this assay, from the lowest: compound 4; then compound 1; then compound 2; then compound 3.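

In this assay, for the compounds shown here, the saturated chain carbon bound to an amine nitrogen and an aromatic carbon emerges as a sensitive position: methyl in place of hydrogen there gives a 14-fold lower number from compound 3 to compound 4 (1.14 log units; beyond the scatter), whereas the only earlier methyl change, on the amine nitrogen, amounts to a 2.2-fold higher number from compound 2 to compound 3 (0.34 log units; beyond the scatter). The (1-phenylethyl)amino group also outdoes the other two amine side chains, with a 6.3-fold lower number from compound 2 to compound 4 (0.80 log units; beyond the scatter) and a 2.7-fold lower number from compound 1 to compound 4 (0.43 log units; beyond the scatter), which makes compound 4 the strongest of the four on these numbers. Nothing available accounts for the size of this step.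

As far as these compounds go, whether the opposite configuration at this carbon keeps the gain remains open, as does the outcome with an ethyl or a hydroxymethyl group there. Also open, from the compounds shown here alone, is whether a methyl on this carbon would act the same way in the benzyl(methyl)amino side chain of compound 2.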